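A few compounds are considered here, and "the series" means these few. Any claim that something is new, unique, unknown or untested is made for them only; others in the source may bear on it.

Measured so far:
- compound 1 `ClCc1ccccc1Cn1cnc2c(Cl)nc(Cl)nc21` in a functional assay on NCI-H522 cells (Homo sapiens) for cytotoxicity, read by sulforhodamine B assay, with a stated time of 48 h (on this read-out lower numbers stand for stronger inhibition of growth and higher numbers for weaker inhibition of growth), gives 1990 nM
- compound 2 `ClCc1ccc(Cn2cnc3nc(Cl)nc(Cl)c32)cc1` in this assay gives 4570 nM
- compound 3 `ClCc1cccc(Cn2cnc3c(Cl)nc(Cl)nc32)c1` in this assay gives 5370 nM

The three measured compounds share a core and differ in where the chloromethyl group sits on the benzyl ring. Compound 2 stands second highest of the three numbers. Its nearest neighbour is compound 3, whose value lies within the usual scatter of compound 2, so the two cannot be told apart. Compound 1 has the lowest number, and its gap from compound 2 is beyond the scatter, so compound 1 inhibits growth more strongly than compound 2.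

Compound 4 `ClCc1ccc(Cn2cnc3ncnc(Cl)c32)cc1` has not yet been measured. It differs from compound 2 in one place: hydrogen in place of chloro on an aromatic carbon of the core. Among the compounds with values here, no measured pair shows this change, so no step size can be taken from the data. The expectation is a modest step from compound 2 to compound 4 towards weaker growth inhibition, estimated as a 1.6-fold higher number from compound 2 to compound 4 (0.22 log units; within the scatter). On that basis compound 4 is expected to give about 7500 nM in this assay, with a range from 2500 nM to 22000 nM.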

Compound 4, concentration for total growth inhibition: > 100000 nM
Compound 4 ended at the assay's limit (the forecaster's own chance of this, stated with the estimate: 10%); middle value at least 13-fold (1.12 log units) from the limit.
By their numbers in this assay, from the lowest: compound 1; then compounds 2 and 3 (each within the scatter of the next). At a limit, above all of these: compound 4.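

In this assay, the chloro group on the aromatic carbon between two ring nitrogen atoms proves to matter a great deal: replacing it with hydrogen gives an at least 21-fold higher number from compound 2 to compound 4 (1.34 log units; beyond the scatter). For compound 4, the value > 100000 nM is a limit of the assay and not a number: the limit of > 100000 nM in this assay, at which 1 of the 4 values shown sits. The earlier compounds shown here all kept this chloro group and differed only in where the chloromethyl group sits on the benzyl ring, so they could not show that the growth inhibition seen with compound 2 depends so heavily on this one atom of the core.

Among the compounds shown, only chloro and hydrogen occupy this position, so it remains open whether a fluoro group, a methoxy group or an amine there would retain growth inhibition or lose it as hydrogen does. Within the data shown here, it also remains open whether the same change would have a similar effect on compound 1 and compound 3, since this single pair, with its chloromethyl group in one place on the benzyl ring, is the only evidence for it.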